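Swapping the Sulfonyl Aryl Group in a Hydrazide Series

The compounds below may be only part of what the source reports. "The series", "measured", "known", "first", "only" and "open" are said of these compounds alone.

Compound 1 `CC(=O)Nc1ccc(S(=O)(=O)NNC(=O)c2cccnc2Nc2ccc(Cl)cc2)cc1` — > 100000 nM
Compound 2 `O=C(NNS(=O)(=O)c1ccc(F)cc1)c1cccnc1Nc1ccc(Cl)cc1Cl` — > 100000 nM

In a functional assay on EKVX cells (Homo sapiens) for antiproliferative activity (on this read-out lower numbers stand for stronger inhibition of growth and higher numbers for weaker inhibition of growth), compound 1 gives > 100000 nM, which is a limit of the assay rather than a number. Compound 2 likewise gives > 100000 nM, again a limit. Both measured values therefore sit at the same edge of the assay, as captured by the limit of > 100000 nM in this assay, at which 2 of the 2 values shown sit, and neither compound shows measurable inhibition of growth in this assay.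

Compound 3 `O=C(NNS(=O)(=O)c1ccc(Cl)cc1Cl)c1cccnc1Nc1ccc(Cl)cc1` has not yet been measured. It differs from compound 1 in one place: 2,4-dichlorophenyl in place of 4-acetamidophenyl on a sulfonyl sulfur. Among the compounds with values here, no step between measured compounds is known, and compound 2 differs from both in more than one place, so no measured effect of this kind of change can be pointed to. The step of a number no higher from compound 1 to compound 3 (the limit leaves the size open) is expected to stay within the usual scatter. For compound 3 the estimate is 100000 nM, with a range from 20000 nM to 500000 nM, and a limit is expected as the likeliest outcome.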

Compound 3, concentration for total growth inhibition: > 100000 nM
Compound 3: no number, only a limit (the forecaster's own chance of this, stated with the estimate: 80%); the middle value lies on the limit itself.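

Compound 1 and compound 3 both end at a limit of the assay rather than a number, so the step between them cannot be read: the limit of > 100000 nM in this assay, at which 3 of the 3 values shown sit.

The compounds shown leave open how strongly any of them inhibits growth, and whether 2,4-dichlorophenyl or 4-acetamidophenyl on a sulfonyl sulfur makes any difference.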